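The source may report more compounds than this note shows. Statements on the series, on what has been measured and on what is new or still open speak of the compounds shown alone.

Compound 1 `CS/C(=N\C(=O)c1sccc1Cl)NC(=O)c1sccc1Cl` was tested in a functional assay on MCF7 cells (Homo sapiens) for cytotoxicity, read by MTT assay, with a stated time of 72 h (a lower number here means a stronger inhibitor of growth, a higher number a weaker inhibitor of growth), where compound 1 gives 10300 nM. Among the three compounds measured so far it holds the second highest number. Compound 2 `CS/C(=N\C(=O)c1ccco1)NC(=O)c1ccco1` gives 56100 nM in this assay, a higher number that lies beyond the usual scatter, while compound 3 `C[Se]/C(=N\C(=O)c1ccno1)NC(=O)c1ccno1` sits far lower. Compound 4 `C[Se]/C(=N\C(=O)c1sccc1Cl)NC(=O)c1sccc1Cl` has not been measured. It differs from compound 1 in one place: a group of 2 heavy atoms (1 carbon, 1 selenium; no ring) in place of a group of 2 heavy atoms (1 carbon, 1 sulfur; no ring), on a carbon with a double bond to nitrogen. For the measured compounds named here, no measured pair shows this change on its own; compound 3, which also carries the selenium group but on different rings and gives 0.09 nM, is the only hint that the change could lower the number. The step from compound 1 to compound 4 is therefore expected to be a sizeable drop, a 34-fold lower number from compound 1 to compound 4 (1.54 log units; beyond the scatter). For compound 4 the estimate is 300 nM, within a range from 3 nM to 15000 nM.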

Compound 4, concentration for 50% growth inhibition: 300 nM
For compound 4 middle estimate and measured number coincide at the digits printed; low and high end bracket the measured number.
By their numbers in this assay, from the lowest: compound 3; then compound 4; then compound 1; then compound 2.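

With the rings held constant, this pair isolates the selenium group in place of methylsulfanyl on a carbon with a double bond to nitrogen. In this assay, the change gives a 34-fold lower number from compound 1 to compound 4 (1.54 log units; beyond the scatter), so selenium at this position lowers the number on the core of compound 1 without any change to the rings. No measurement shown accounts for this step. For the compounds shown here, whether the same change lowers the number on other rings remains open, since this is the only such pair. Also open, as far as these compounds go, is how a longer chain on the selenium, or an amine on the same carbon, would compare.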